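Thiourea Ethers: Phenoxy for Phenyl, Cytotoxicity Expected Unchanged

This account rests on a few compounds, and the source may have more. Where it says the series, first, only, none or still open, it means among the compounds named here.

Compound 1 `NC(=S)Nc1cccc(OCCCCCOc2cccc(-c3ccccc3)c2)c1` carries a thiourea at one end and a phenyl group at the other. In an ADME assay on Ava5 cells (Homo sapiens) for cytotoxicity (a higher number here means that more compound is tolerated, a lower number that less compound is tolerated), compound 1 gives 13000 nM. Compound 2 `NC(=S)Nc1cccc(OCCCCCOc2ccccc2-c2ccccc2)c1` is a close analogue, and in this assay compound 2 gives 13000 nM, level with compound 1 at the digits shown and within the scatter, so the two values show no difference between them. Compound 3 `NC(=S)Nc1cccc(OCCCCCOc2cccc(Oc3ccccc3)c2)c1` has not yet been measured. It differs from compound 1 by phenoxy in place of phenyl on an aromatic carbon. Among the compounds with values here, no measured pair shows the effect of this change, and the only comparison at hand, compound 1 against compound 2, shows no movement. The step from compound 1 to compound 3 in this assay is therefore expected to be no change at the digits printed from compound 1 to compound 3 (within the scatter), nothing beyond the scatter. Compound 3 is estimated at 13000 nM, with a range from 6000 nM to 30000 nM.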

Compound 3, half-maximal cytotoxic concentration: 18000 nM
For compound 3 the middle estimate is 1.4-fold (0.14 log units) below the measured one; the measured number falls inside the stated range.
By their numbers in this assay, from the lowest: compounds 1, 2 and 3 (each within the scatter of the next).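

The step gives a direct reading of this change at this position, which compounds 1 and 2 alone could not supply. In this assay, phenoxy in place of phenyl on an aromatic carbon, meta to a large group, gives a 1.4-fold higher number from compound 1 to compound 3 (0.14 log units; within the scatter), so adding one oxygen and one hydrogen-bond acceptor at this place leaves the result inside the scatter. Nothing available here bears on why the result falls as it does.

This single pair leaves open whether the same exchange would behave alike with the group elsewhere on the ring or with a longer chain in the core of compound 1. It also leaves open whether an amine or a carboxylic acid at this position would move the number beyond the scatter.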